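A Naphthyl Amide in Place of a Dimethylphenyl Amide

The source may hold more compounds than are shown below. What is called first, only, known or untested is meant among the compounds shown, and "the series" means these compounds.

Of the compounds shown here, three have been measured in a functional assay on U2OS cells (Homo sapiens) for antiproliferative activity, read by MTT assay, with a stated time of 72 h; on this read-out higher numbers stand for weaker inhibition and lower numbers for stronger inhibition. Compound 1 `O=C(CSc1cccc(O)c1)Nc1ccc2nc(NC(=O)c3cc(Cl)cc(Cl)c3)sc2c1` gives 1530 nM in this assay. Compound 3 `Oc1ccc(Cl)cc1/C=N/c1ccc(-c2nc3ccccc3o2)c(O)c1` gives 21700 nM in this assay. Compound 2 `Cc1cc(C)cc(C(=O)Nc2nc3ccc(NC(=O)CSc4ccc(Cl)cc4)cc3s2)c1` reaches only the limit of this assay, > 100000 nM, and not a number. Going by the values given here, it is the single compound that sits at the limit of > 100000 nM in this assay, at which 1 of the 3 values shown sits. Compound 2 therefore stands at the weak end of the three values shown, while compound 1 and compound 3 each give a number.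

Compound 4 `O=C(CSc1ccc(Cl)cc1)Nc1ccc2nc(NC(=O)c3ccc4ccccc4c3)sc2c1` has not yet been measured in this assay. It differs from compound 2 in one place: naphthalen-2-yl in place of 3,5-dimethylphenyl on a carbonyl carbon. The naphthalen-2-yl enters on a carbonyl carbon whose other neighbours are an amide-type nitrogen, and the rest of compound 2 is kept unchanged.

Among the compounds with values here, no step between two measured compounds in this set turns on this group alone, so the size of the step cannot be read from the data. The expected step is an at least 5.0-fold lower number from compound 2 to compound 4 (0.69 log units; beyond the scatter), a move toward stronger inhibition, but with wide uncertainty because compound 2 gives only the limit > 100000 nM. Compound 4 is estimated to give 20000 nM in this assay, within a range from 3000 nM to 100000 nM, and it may again reach only the limit.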

Compound 4, half-maximal inhibitory concentration: 14500 nM
Beside the measured number, compound 4's estimate is 1.4-fold (0.14 log units) above it; the measured number falls inside the stated range.
By their numbers in this assay, from the lowest: compound 1; then compounds 4 and 3 (each within the scatter of the next). At a limit, above all of these: compound 2.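

In this assay, going by these compounds alone, naphthalen-2-yl in place of 3,5-dimethylphenyl on a carbonyl carbon gives an at least 6.8-fold lower number from compound 2 to compound 4 (0.83 log units; beyond the scatter), the first step in this set to show that this place responds to a change of group. Here 3,5-dimethylphenyl, with one six-membered aromatic ring of carbon only, gives way to naphthalen-2-yl, with 2 such rings, and neither group carries a hydrogen-bond donor, a hydrogen-bond acceptor or a net charge. The size of the step remains a bound and not a number because compound 2 gives a limit: the limit of > 100000 nM in this assay, at which 1 of the 4 values shown sits.

The compounds shown leave open whether the second aromatic ring itself or the loss of the two methyl groups goes with the stronger inhibition, a question that a plain phenyl or a cyclohexyl group on the same carbonyl carbon would help to separate. They also leave open how an amine or a carboxylic acid carried on this aromatic group would shift the number.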